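A few compounds are considered here, and "the series" means these few. Any claim that something is new, unique, unknown or untested is made for them only; others in the source may bear on it.

Measured so far in a functional assay on PC-3 cells (Homo sapiens) for antiproliferative activity, read by sulforhodamine B assay, with a stated time of 3 days; on this read-out higher numbers stand for an effect only at larger amounts of compound and lower numbers for an effect already at smaller amounts:
- compound 1, `CCCC1(CC=C(C)C)C(=O)C(C(=O)/C=C/c2ccccc2)=C(O)C(CCC)(CCC)C1=O`: 8.4 uM
- compound 2, `CCCC1=C(OCC(C)C)C(CCC)(CCC)C(=O)/C(=C(O)\C=C\c2ccccc2)C1=O`: 12.2 uM
- compound 3, `COC1=C(CCC(C)C)C(=O)/C(=C(O)/C=C/c2ccccc2)C(=O)C1(CCC(C)C)CCC(C)C`: "not active" (no number reported) (reported without a number)

Compound 2 gives the highest of the two numbers on record in this assay. The nearest entry is compound 1, whose number is lower than that of compound 2 by an amount that lies within the scatter, so the two cannot be told apart on these data. Among the compounds with values here, compound 3 adds a third entry without a single number, and its result stands alone, as no step from compound 2 to compound 3 has been worked out.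

The step now under consideration runs from compound 2 to compound 4, `CCCC1=C(OC)C(CCC)(CCC)C(=O)/C(=C(O)\C=C\c2ccccc2)C1=O`. The change is hydrogen in place of isopropyl on a saturated chain carbon bound to an oxygen on an unsaturated carbon: isobutoxy becomes methoxy. Within the data shown here, no step between measured compounds is on record, so the size of this move has to be expected rather than read off. The expectation for compound 4 in this assay is a step of a 1.2-fold higher number from compound 2 to compound 4 (0.09 log units; within the scatter), that is, no clear movement beyond the scatter, with the result for compound 3 as a caution that a methoxy-bearing compound in this series may fail to give a number. Compound 4 is therefore estimated at 15 uM, with a range from 5 uM to 50 uM.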

Compound 4, concentration for half-maximal effect: 8.2 uM
Beside the measured number, compound 4's estimate is 1.8-fold (0.26 log units) above it; the measured number falls inside the stated range.
By their numbers in this assay, from the lowest: compounds 4, 1 and 2 (each within the scatter of the next).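

Within the data shown here, the first step on record is a 1.5-fold lower number from compound 2 to compound 4 (0.17 log units; within the scatter) in this assay: with hydrogen in place of isopropyl on a saturated chain carbon bound to an oxygen on an unsaturated carbon, methoxy and isobutoxy cannot be told apart. The earlier compounds shown here gave no reading at this position, and the chain on this oxygen can now be cut from isobutyl to methyl with a number still obtained. Nothing at hand offers an explanation for this result.

Going by these compounds, whether the same holds for a longer chain such as hexyloxy, for a chain ending in an amine or a carboxylic acid, or for a free hydroxyl on this carbon remains open. Compound 3 differs from compound 4 in more than one place, so what separates a result with a number from one without stays unresolved.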